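The compounds below may be only part of what the source reports. "The series", "measured", "known", "first", "only" and "open" are said of these compounds alone.

For the measured compounds named here, in an ADME assay for permeability, using PAMPA, with a stated time of 4 h, at pH 5.5 (a lower number here means that the compound crosses the layer more slowly, a higher number that the compound crosses the layer faster), compound 1 `NCCCCN(C[C@H]1Cc2ncccc2CN1)[C@H]1CCCc2cccnc21` gives 17 nm/s, while compound 2 `NC/C=C/CN(C[C@H]1Cc2ncccc2CN1)[C@H]1CCCc2cccnc21` gives 2 nm/s, the lower of the two numbers so far. Compound 3 `NC(=O)NC/C=C/CN(C[C@H]1Cc2ncccc2CN1)[C@H]1CCCc2cccnc21` follows from compound 2 by placing carbamoyl in place of hydrogen on an amine nitrogen, turning amino into ureido (carbamoyl in place of hydrogen on an amine nitrogen). Going by the values given here, the only measured step is an 8.5-fold lower number from compound 1 to compound 2 (0.93 log units; beyond the scatter), with 3-aminoprop-1-en-1-yl in place of 3-aminopropyl. That step changes a different place, so it bears only indirectly: it shows that one change in the chain can move this assay beyond the scatter. Among the compounds with values here, no measured pair shows the effect of carbamoyl, so the direction is uncertain, though a modest rise, smaller than that step, is expected. The estimated change is a 3.0-fold higher number from compound 2 to compound 3 (0.48 log units; beyond the scatter). Compound 3 is expected to read 6 nm/s, within an estimated range of 1.5 nm/s to 25 nm/s.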

Compound 3, apparent permeability: 6 nm/s
Compound 3: the middle estimate sits on the measured number at the digits printed, and the stated range covers the measured number.
By their numbers in this assay, from the lowest: compound 2; then compound 3; then compound 1.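

In this assay, carbamoyl in place of hydrogen on the amine nitrogen gives a 3.0-fold higher number from compound 2 to compound 3 (0.48 log units; beyond the scatter), so this nitrogen, unlike the chain changed in the earlier step, is a place where a change raises the number beyond the scatter. The rise does not bring the number back to where the saturated chain stood, since a 2.8-fold lower number from compound 1 to compound 3 (0.45 log units; beyond the scatter) still lies beyond the scatter. Nothing measured here accounts for either step.

On these data alone, whether the rise belongs to carbamoyl itself or would also follow from another group on this nitrogen, such as acetyl or methanesulfonyl, stays open. Also open, as far as these compounds go, is whether ureido would give a step of like size on the 3-aminopropyl chain, or on a longer chain.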